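Amide-nitrogen variation in an acrylamide series: compound 3 to 4

The source may report more compounds than this note shows. Statements on the series, on what has been measured and on what is new or still open speak of the compounds shown alone.

The series shares a core carrying a terminal acrylamide and a chloro substituent, with variation confined to the amide built on the aniline. Compound 1 `C=CC(=O)Nc1ccc(-c2nc(Cl)cc(Nc3ccc(C(=O)N(CC)CC)cc3)n2)cc1` gives 11200 nM in a functional assay on Ramos cells (Homo sapiens) for antiproliferative activity, read by MTT assay, with a stated time of 48 h; a higher number here means a weaker inhibitor, a lower number a stronger inhibitor. Compound 2 `C=CC(=O)Nc1ccc(-c2nc(Cl)cc(Nc3ccc(C(=O)N(C)C)cc3)n2)cc1` is recorded only as a limit of this assay, > 50000 nM. Within the data shown here, the step of an at least 4.4-fold higher number from compound 1 to compound 2 (0.64 log units; beyond the scatter) is the only measured step; it rests on (the limit of > 50000 nM in this assay, at which 1 of the 3 values shown sits), so its true size is unknown. For compound 3 `C=CC(=O)Nc1ccc(-c2nc(Cl)cc(Nc3ccc(C(=O)Nc4ccc(F)cc4)cc3)n2)cc1` the entry in this assay reads "not determined" (no result reported), so compound 3 stands nowhere on the numbers shown. Compound 4 `C=CC(=O)Nc1ccc(-c2nc(Cl)cc(Nc3ccc(C(=O)Nc4cc(C)ccc4C)cc3)n2)cc1` differs from compound 3 by 2,5-dimethylphenyl in place of 4-fluorophenyl on an amide-type nitrogen. Among the measured compounds shown here, no measured step touches an aryl group on the amide nitrogen; the one step known concerns alkyl groups on the same position and is itself open-ended. No direction can be taken from it for the change from compound 3 to compound 4. Given that both measured compounds sit at the weak end, compound 4 is estimated at 20000 nM, with an expected range from 4000 nM to 60000 nM, and a real chance that only a limit is returned.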

Compound 4, half-maximal inhibitory concentration: 16800 nM
For compound 4 the middle estimate is 1.2-fold (0.08 log units) above the measured one; low and high end bracket the measured number.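

With compound 4 the amide nitrogen carries an aryl group with a usable reading in this assay, and against the dimethylamino amide this gives an at least 2.9-fold lower number from compound 2 to compound 4 (0.47 log units; beyond the scatter). Compound 2 stands only as a limit, so the true size of that step stays unknown: the limit of > 50000 nM in this assay, at which 1 of the 4 values shown sits.

Against the diethylamino amide the result is a 1.5-fold higher number from compound 1 to compound 4 (0.18 log units; within the scatter), so 2,5-dimethylphenyl amino and diethylamino on this carbonyl carbon cannot be told apart in this assay.

Steps to compound 3 cannot be read, which leaves 4-fluorophenyl and 2,5-dimethylphenyl on the amide nitrogen without a comparison. On these data alone, how a morpholine amide, or an aryl amide carrying a carboxylic acid, would read at this position remains open.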